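Shortening the Alkyl Chain in a Pyrrolidine Series

This account rests on a few compounds, and the source may have more. Where it says the series, first, only, none or still open, it means among the compounds named here.

Measured compounds:
- compound 1, `CCCCCCCCC[C@]1(CO)NC[C@@H](O)[C@@H]1O`: 2.5%
- compound 2, `Cc1ccc([C@@]2(CO)NC[C@H](O)[C@H]2O)cc1`: 0%
- compound 3, `OC[C@@]1(c2c(F)c(F)c(F)c(F)c2F)NC[C@@H](O)[C@@H]1O`: 0%

Of the compounds shown here, three sharing the same core have been tested in an assay on isolated protein for inhibition of alpha-galactosidase (Coffea arabica), tested at 1000 uM; on this read-out higher numbers stand for more inhibition at the one concentration tested (going by the name of the read-out) and lower numbers for less inhibition. Compound 1 gives 2.5%, compound 2 gives 0% and compound 3 gives 0%. Compound 1 carries the highest of the three numbers, but its gap to compound 2 and its gap to compound 3 both lie within the usual scatter of this assay, so the three readings cannot be told apart.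

The next compound, compound 4, `CCCC[C@]1(CO)NC[C@@H](O)[C@@H]1O`, keeps the core of compound 1 and differs from it in one place: hydrogen in place of pentyl on a saturated chain carbon, four bonds along the chain from a saturated ring carbon. Within the data shown here, no step between two measured compounds is available to gauge such a change, and all three measured numbers sit near the floor of the read-out. The step is therefore expected to be a number 1.5 percentage points lower from compound 1 to compound 4 (within the scatter), no larger than the scatter. Compound 4 is estimated at 1%, between 0% and 10%.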

Compound 4, a percentage reported as inhibition, at one concentration (the size of the read-out at that concentration, not a potency): 4.6%
The estimate for compound 4 lay 3.6 percentage points below the measured number; low and high end bracket the measured number.
By their numbers in this assay, from the lowest: compounds 2, 3, 1 and 4 (each within the scatter of the next).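

In this assay, hydrogen in place of pentyl on a saturated chain carbon, four bonds along the chain from a saturated ring carbon, gives a number 2.1 percentage points higher from compound 1 to compound 4 (within the scatter). Among these compounds, this is the first step that changes one place only, and it shows that losing the pentyl group leaves the reading in the same narrow band near the floor of the read-out, with no change that can be told from the scatter. No experimental evidence here bears on the reason for this outcome.

On these data alone, what remains open is whether an amine or a carboxylic acid in place of pentyl would give a reading that stands clear of the scatter. It is also open whether a longer chain would do so, since the compounds shown give no reading that stands clear of the others.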